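Acylurea hydrazone series: aryl change on the carbonyl

The source may hold more compounds than are shown below. What is called first, only, known or untested is meant among the compounds shown, and "the series" means these compounds.

Measured so far:
compound 1, `CN(C(=O)NC(=O)c1ccc(Cl)cc1Cl)c1nc(C(F)(F)F)c(C(=O)N/N=C/c2ccc(C(F)(F)F)cc2)s1`, gives 3.08 ug/mL in a functional assay on BCG823 cells (Homo sapiens) for inhibition, read by MTT assay, with a stated time of 72 h; a higher number here means a weaker inhibitor, a lower number a stronger inhibitor.
compound 2, `CN(C(=O)NC(=O)c1ccc(Cl)cc1Cl)c1nc(C(F)(F)F)c(C(=O)N/N=C/c2ccccc2C(F)(F)F)s1`, gives 5.73 ug/mL in this assay.

Within the data shown here, compound 2 holds the higher of the two numbers, but the only step, a 1.9-fold higher number from compound 1 to compound 2 (0.27 log units; within the scatter), lies within the scatter, so the two compounds read as equal. Compound 3, `CN(C(=O)NC(=O)c1ccc(C(F)(F)F)cc1)c1nc(C(F)(F)F)c(C(=O)N/N=C/c2ccccc2C(F)(F)F)s1`, differs from compound 2 by 4-(trifluoromethyl)phenyl in place of 2,4-dichlorophenyl on a carbonyl carbon. Among the measured compounds shown here, no measured step touches this carbonyl-side aryl group; the single step concerns the hydrazone side. No direction beyond the scatter is therefore expected. Compound 3 is estimated at 5.5 ug/mL, with a range of 2 ug/mL to 15 ug/mL. The expected step is a 1.0-fold lower number from compound 2 to compound 3 (0.02 log units; within the scatter).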

Compound 3, half-maximal inhibitory concentration: 2.53 ug/mL
Beside the measured number, compound 3's estimate is 2.2-fold (0.34 log units) above it, and the stated range covers the measured number.
By their numbers in this assay, from the lowest: compounds 3, 1 and 2 (each within the scatter of the next, the first and the last beyond it).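

Among these compounds, the carbonyl-side aryl group gives the first step that lies beyond the scatter: 4-(trifluoromethyl)phenyl in place of 2,4-dichlorophenyl gives a 2.3-fold lower number from compound 2 to compound 3 (0.36 log units; beyond the scatter) in this assay as a modest change. This reading rests on one pair, with the 2-(trifluoromethyl)phenyl hydrazone held fixed. Nothing available bears on the reason for this step.

As far as these compounds go, whether the same carbonyl-side change carries over to the 4-(trifluoromethyl)phenyl hydrazone of compound 1 remains open. Also open, from the compounds shown here alone, is how a carbonyl-side phenyl carrying a methoxy group or a nitrile would read.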